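Return to a Benzyl-Type Substituent at the Ring Nitrogen

A few compounds are considered here, and "the series" means these few. Any claim that something is new, unique, unknown or untested is made for them only; others in the source may bear on it.

The measured compounds:
- compound 1, `Nc1nc(O)c2c(n1)n(C1OC(CO)[C@@H](O)[C@H]1O)c(=O)n2Cc1ccccc1`: 6 uM
- compound 2, `CCCCn1c(=O)n(C2OC(CO)[C@@H](O)[C@H]2O)c2nc(N)nc(O)c21`: 11 uM
- compound 3, `[N-]=[N+]=NCC(O)Cn1c(=O)n(C2OC(CO)[C@@H](O)[C@H]2O)c2nc(N)nc(O)c21`: 39 uM

In a functional assay (B cells) with Mus musculus as the target (on this read-out higher numbers stand for an effect only at larger amounts of compound and lower numbers for an effect already at smaller amounts), compound 3 gives the highest number of the three. The distances are a 6.5-fold higher number from compound 1 to compound 3 (0.81 log units; beyond the scatter) and a 3.5-fold higher number from compound 2 to compound 3 (0.55 log units; beyond the scatter), both beyond the scatter, so compound 3 is the least potent of the measured set. The gap between compound 1 and compound 2 is a 1.8-fold higher number from compound 1 to compound 2 (0.26 log units; within the scatter), within the scatter.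

Compound 4, `N#Cc1ccc(Cn2c(=O)n(C3OC(CO)[C@@H](O)[C@H]3O)c3nc(N)nc(O)c32)cc1`, differs from compound 3 as follows: 4-cyanophenyl in place of 2-azido-1-hydroxyethyl on a saturated chain carbon bound to an aromatic nitrogen. Among the compounds with values here, the step bearing most directly on this change is the one from compound 1 to compound 3, which moved the number up by a 6.5-fold higher number from compound 1 to compound 3 (0.81 log units; beyond the scatter) when phenyl gave way to 2-azido-1-hydroxyethyl. Compound 4 carries 4-cyanophenyl at the same place, which is close to the phenyl of compound 1, so the expectation is that most of that step is reversed. Compound 4 is therefore expected to show a modest step down in this assay, estimated as a 4.9-fold lower number from compound 3 to compound 4 (0.69 log units; beyond the scatter). The estimate for compound 4 in this assay is 8 uM, with a range from 3 uM to 25 uM.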

Compound 4, concentration for half-maximal effect: 15 uM
Compound 4: middle estimate off by 1.9-fold (0.27 log units), on the low side; low and high end bracket the measured number.
By their numbers in this assay, from the lowest: compounds 1, 2 and 4 (each within the scatter of the next, the first and the last beyond it); then compound 3.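

In this assay the step of a 2.6-fold lower number from compound 3 to compound 4 (0.41 log units; beyond the scatter) shows that an aromatic group at this place, here 4-cyanophenyl in place of 2-azido-1-hydroxyethyl, recovers part of the distance that the azido chain had opened, though not all of it. Within the data shown here, the step of a 2.5-fold higher number from compound 1 to compound 4 (0.40 log units; beyond the scatter) is the first change made on the aromatic ring itself rather than a swap of the whole group, and it shows that cyano in place of hydrogen on an aromatic carbon is enough to move the number beyond the scatter. The step of a 1.4-fold higher number from compound 2 to compound 4 (0.13 log units; within the scatter) stays within the scatter, so 4-cyanophenyl and propyl cannot be told apart at this place, and an aromatic ring is not required for a number in this range.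

Going by these compounds, with a single ring substituent in view, it remains open whether the shift belongs to the nitrile specifically or would also appear with a chlorine, a methoxy group or an amine in its place on the ring. The information available offers no account of why any of these steps has the size it has.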